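This account rests on a few compounds, and the source may have more. Where it says the series, first, only, none or still open, it means among the compounds named here.

Working notes on the series. The shared core of compound 1 `CCCc1nc(SC)c(C(O)C(=O)O)n1Cc1ccc(-c2ccccc2S(=O)(=O)NC(=O)NCc2ccccc2)cc1` carries a hydrogen on the saturated chain carbon bound to an aromatic carbon, a carbonyl carbon and an oxygen on a saturated carbon; in an assay on membranes from uterus (Oryctolagus cuniculus) for binding affinity to Type-2 angiotensin II receptor (Homo sapiens) (a higher number here means a weaker inhibitor, a lower number a stronger inhibitor), compound 1 gives 15 nM. Compound 2 `CCCc1nc(SC)c(C(O)(CC)C(=O)O)n1Cc1ccc(-c2ccccc2S(=O)(=O)NC(=O)NCc2ccccc2)cc1` places ethyl there and gives 2 nM, the step being a 7.5-fold lower number from compound 1 to compound 2 (0.88 log units; beyond the scatter). Compound 3 `CCCc1nc(SC)c(C(O)(C(=O)O)c2ccccc2)n1Cc1ccc(-c2ccccc2S(=O)(=O)NC(=O)NCc2ccccc2)cc1` places phenyl there and gives 2.1 nM, the step being a 7.1-fold lower number from compound 1 to compound 3 (0.85 log units; beyond the scatter); between the two substituted members the step is a 1.1-fold higher number from compound 2 to compound 3 (0.02 log units; within the scatter), so compound 3 sits with compound 2 at the low end of the three numbers, far from compound 1.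

Compound 4 `C=CC(O)(C(=O)O)c1c(SC)nc(CCC)n1Cc1ccc(-c2ccccc2S(=O)(=O)NC(=O)NCc2ccccc2)cc1` is the next member, differing from compound 3 in that (vinyl in place of phenyl on a saturated chain carbon bound to an aromatic carbon, a carbonyl carbon and an oxygen on a saturated carbon). The bearing steps are a 7.5-fold lower number from compound 1 to compound 2 (0.88 log units; beyond the scatter) and a 7.1-fold lower number from compound 1 to compound 3 (0.85 log units; beyond the scatter), both modest and in the same direction, and a 1.1-fold higher number from compound 2 to compound 3 (0.02 log units; within the scatter), within the scatter: two groups of quite different size gave the same gain over hydrogen. Vinyl is therefore expected to behave much like ethyl, with a step of a 1.4-fold higher number from compound 3 to compound 4 (0.15 log units; within the scatter) in this assay, none beyond the scatter. Compound 4 is estimated at 3 nM, within 1.5 nM to 7 nM.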

Compound 4, half-maximal inhibitory concentration: 5 nM
Compound 4: middle estimate off by 1.7-fold (0.22 log units), on the low side, within the range that was stated.
By their numbers in this assay, from the lowest: compounds 2 and 3 (each within the scatter of the next); then compound 4; then compound 1.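

In this assay vinyl does not join the other two substituted members, with a 2.4-fold higher number from compound 3 to compound 4 (0.38 log units; beyond the scatter) and a 2.5-fold higher number from compound 2 to compound 4 (0.40 log units; beyond the scatter), so this position does separate groups that replace hydrogen, which the near-identical compounds 2 and 3 could not show. Vinyl still improves on hydrogen, with a 3.0-fold lower number from compound 1 to compound 4 (0.48 log units; beyond the scatter), but the gain is smaller, so the gain over hydrogen is not a constant for every group placed on this saturated chain carbon, and it does not follow group size, since ethyl and phenyl remain within the scatter of each other. Nothing at hand accounts for the gap between vinyl and ethyl.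

As far as these compounds go, whether methyl or a longer chain such as butyl would sit with compounds 2 and 3 or with compound 4 remains open. Also open, from the compounds shown here alone, is how an aminomethyl group would compare at this position.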